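The compounds below may be only part of what the source reports. "The series", "measured", "known", "first", "only" and "open" are said of these compounds alone.

Working notes on the series.

Compound 1 `O=S(=O)(/C=C/c1ccccc1)Cc1ccc(Nc2ncnc3ccccc23)cc1` is the unsubstituted parent. In a functional assay on HT-29 cells (Homo sapiens) (on this read-out higher numbers stand for weaker inhibition of growth and lower numbers for stronger inhibition of growth), compound 1 returns only a limit of the assay, > 100000 nM. Compound 2 `O=S(=O)(/C=C/c1ccc(Cl)cc1)Cc1ccc(Nc2ncnc3ccccc23)cc1` carries a chloro in place of hydrogen on an aromatic carbon and gives 73000 nM in this assay, which is an at least 1.3-fold lower number from compound 1 to compound 2 (0.13 log units; that floor lies within the scatter). Compound 3 `O=S(=O)(/C=C/c1ccc(F)cc1F)Cc1ccc(Nc2ncnc3ccccc23)cc1` returns a limit of the assay in this assay, > 100000 nM. The step from the parent, a step that the two limits leave unreadable from compound 1 to compound 3, cannot be sized; against the chloro analogue the step is an at least 1.3-fold higher number from compound 2 to compound 3 (0.13 log units; that floor lies within the scatter). Going by the values given here, the whole picture is shaped by the limit of > 100000 nM in this assay, at which 2 of the 3 values shown sit, so none of the measured steps can be read as a real change.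

Compound 4 `O=S(=O)(/C=C/c1ccc(C(F)(F)F)cc1F)Cc1ccc(Nc2ncnc3ccccc23)cc1` is the next analogue. The change from compound 1 is 2-fluoro-4-(trifluoromethyl)phenyl in place of phenyl on a double-bonded chain carbon bound to a double-bonded chain carbon. The closest comparison is compound 3, whose 2,4-difluorophenyl analogue sits at the limit, > 100000 nM, while compound 2 with 4-chlorophenyl gives 73000 nM; neither points to a step beyond the scatter. For compound 4 the expected step is therefore an at least 1.1-fold lower number from compound 1 to compound 4 (0.04 log units; that floor lies within the scatter), within scatter and with a high chance that only a limit is reported. Compound 4 is estimated at 90000 nM in this assay, with a range from 40000 nM to 200000 nM.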

Compound 4, concentration for 50% growth inhibition: 100000 nM
Estimate against measurement, compound 4: 1.1-fold (0.05 log units) below; measured number inside the range.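

In this assay, 2-fluoro-4-(trifluoromethyl)phenyl, with 11 heavy atoms in place of the 6 of phenyl, can stand on a double-bonded chain carbon bound to a double-bonded chain carbon and still give a readable number rather than a limit of the assay, with a number no higher from compound 1 to compound 4 (the limit leaves the size open). Against the 4-chlorophenyl analogue the comparison is a 1.4-fold higher number from compound 2 to compound 4 (0.14 log units; within the scatter), so the two readable values in the series cannot be told apart, and trifluoromethyl with fluoro on the ring gives no separation from chloro. With trifluoromethyl in place of fluoro on an aromatic carbon the comparison is a number no higher from compound 3 to compound 4 (the limit leaves the size open). The size of this step and of the step from the parent cannot be read, and no aryl change at this place has yet been shown to move the read-out beyond the scatter, a reading that rests on one feature of the data: the limit of > 100000 nM in this assay, at which 2 of the 4 values shown sit.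

Going by these compounds, whether any group at this place can give a step beyond the scatter stays open, for example a phenyl carrying an amine or a carboxylic acid. Also open, on these data alone, is whether a change on the shared core, rather than on this aryl group, would move the number in this assay.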